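Acyl and sulfonyl variation on a long-chain threonine amide

The source may hold more compounds than are shown below. What is called first, only, known or untested is meant among the compounds shown, and "the series" means these compounds.

Measured so far in a functional assay on MCF7 cells (Homo sapiens) for cytotoxicity, read by MTT assay, with a stated time of 48 h; on this read-out lower numbers stand for stronger inhibition and higher numbers for weaker inhibition:
compound 1, `CCCCCCCCCCCCCCNC(=O)[C@@H](N)[C@@H](C)O`: 10700 nM
compound 2, `CCCCCCCCCCCCCCNC(=O)[C@@H](NC(=O)c1cc2ccccc2[nH]1)[C@@H](C)O`: 15100 nM
compound 3, `CCCCCCCCCCCCCCNC(=O)[C@@H](NC(=O)/C=C/c1ccccc1)[C@@H](C)O`: 64600 nM

Compound 3 stands at the highest number of the three in this assay. The two steps leading to it, a 6.0-fold higher number from compound 1 to compound 3 (0.78 log units; beyond the scatter) and a 4.3-fold higher number from compound 2 to compound 3 (0.63 log units; beyond the scatter), are both beyond the scatter, whereas a 1.4-fold higher number from compound 1 to compound 2 (0.15 log units; within the scatter) is within it, so compound 1 and compound 2 cannot be ordered against each other.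

The next compound, compound 4, `CCCCCCCCCCCCCCNC(=O)[C@@H](NS(=O)(=O)c1cccs1)[C@@H](C)O`, differs from compound 3 in one place: (thiophen-2-yl)sulfonyl in place of (2-phenylethenyl)carbonyl on an amine nitrogen. Among the compounds with values here, no measured step exchanges one substituent on this amine nitrogen for another of a different kind, so the evidence is indirect. What the series does show is that the (2-phenylethenyl)carbonyl group is associated with the highest number, because a 6.0-fold higher number from compound 1 to compound 3 (0.78 log units; beyond the scatter) and a 4.3-fold higher number from compound 2 to compound 3 (0.63 log units; beyond the scatter) both run upward on arrival at compound 3. Taking that group away is therefore expected to bring the number back toward the range of compound 1 and compound 2, and the expected step is a 3.2-fold lower number from compound 3 to compound 4 (0.51 log units; beyond the scatter), a modest fall in the number rather than a further rise. Compound 4 is accordingly estimated at 20000 nM in this assay, with an expected range from 7000 nM to 60000 nM.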

Compound 4, half-maximal inhibitory concentration: 18700 nM
For compound 4 the middle estimate is 1.1-fold (0.03 log units) above the measured one; low and high end bracket the measured number.
By their numbers in this assay, from the lowest: compounds 1, 2 and 4 (each within the scatter of the next); then compound 3.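

In this assay this amine nitrogen now carries a sulfonyl group rather than a carbonyl-linked one, and the exchange gives a 3.5-fold lower number from compound 3 to compound 4 (0.54 log units; beyond the scatter) and so shows that the high number of compound 3 does not extend to every substituent placed here. The (thiophen-2-yl)sulfonyl group cannot be told apart from the free amine, with a 1.7-fold higher number from compound 1 to compound 4 (0.24 log units; within the scatter) and a comparison to the (1H-indol-2-yl)carbonyl group giving a 1.2-fold higher number from compound 2 to compound 4 (0.09 log units; within the scatter) as well, so compounds 1, 2 and 4 form one level and compound 3 is the only one of the four that goes against it. No measurement at hand accounts for the separate position of the (2-phenylethenyl)carbonyl group.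

Still open, going by these compounds, is whether the change in number belongs to the sulfonyl link or to the thiophene ring, which a (thiophen-2-yl)carbonyl group or a phenylsulfonyl group on the same nitrogen would separate. Also open, on these data alone, is whether the carbon-carbon double bond of the (2-phenylethenyl)carbonyl group matters, as a 3-phenylpropanoyl group would show, and whether any substituent on this nitrogen gives a number clearly lower than that of compound 1.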